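This account rests on a few compounds, and the source may have more. Where it says the series, first, only, none or still open, it means among the compounds named here.

Measured compounds in a functional assay on the whole organism (artery, strain albino) with Rattus norvegicus as the target, with a stated time of 360 min, at a dose of 10 mg/kg by the oral route; on this read-out lower numbers stand for less inhibition and higher numbers for more inhibition at the one dose given (going by the name of the read-out):
- compound 1 `CC1=C(C(=O)Nc2ccc([N+](=O)[O-])cc2)C(c2ccc(Br)cc2)N=C(SCc2cccc(Cl)c2)N1`: 7.2%
- compound 2 `CC1=C(C(=O)Nc2ccc([N+](=O)[O-])cc2)C(c2ccc(Br)cc2)N=C(SCc2ccc(Cl)cc2)N1`: 39.2%

Among the measured compounds shown here, compound 1 stands lowest of the two numbers in this assay; its nearest neighbour is compound 2, and the step of a number 32 percentage points higher from compound 1 to compound 2 (beyond the scatter) is the only measured step. That step concerns the 4-chlorophenyl in place of 3-chlorophenyl on a saturated chain carbon bound to a sulfur.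

Compound 3 `CC1=C(C(=O)Nc2ccc([N+](=O)[O-])cc2)C(c2cccc([N+](=O)[O-])c2)N=C(SCc2cccc(Cl)c2)N1` has not yet been measured in this assay. It differs from compound 1 as follows: 3-nitrophenyl in place of 4-bromophenyl on a saturated ring carbon. This change sits on a saturated ring carbon of the shared core, not on the chain carbon bound to a sulfur that the step from compound 1 to compound 2 concerned. For the measured compounds named here, no measured step therefore bears on it, and the series gives no ground for expecting a step beyond the scatter in either direction; the range of the estimate is kept wide to reflect that.

The step expected for compound 3 is a number 7.8 percentage points higher from compound 1 to compound 3 (within the scatter). Compound 3 is estimated at 15%, with a range from 0% to 40%.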

Compound 3, a percentage reported as inhibition, in the whole organism at one dose (the size of the read-out at that dose, not a potency): 21.6%
Compound 3: middle estimate off by 6.6 percentage points, on the low side, within the range that was stated.
By their numbers in this assay, from the lowest: compound 1; then compound 3; then compound 2.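

In this assay, the saturated ring carbon of the shared core now responds to a change of its aryl group, as 3-nitrophenyl in place of 4-bromophenyl gives a number 14.4 percentage points higher from compound 1 to compound 3 (beyond the scatter) with the (3-chlorobenzyl)sulfanyl group held fixed. Among the compounds shown here, until now the only readable change lay on the chain carbon bound to a sulfur, where the step is a number 32 percentage points higher from compound 1 to compound 2 (beyond the scatter); with compound 1 as the common reference, two places now carry steps beyond the scatter, the ring-carbon step being the modest one and the chain-carbon step the large one. Nothing measured on these compounds accounts for either step, so the size of the new one stays unexplained.

The new group differs from the old one in both its substituent and where that substituent is printed in the name, so a 3-bromophenyl or a 4-nitrophenyl group on this ring carbon would be needed to separate the two changes. Also open, on these data alone, is whether a plain phenyl or a 3-aminophenyl group fits the same trend, and whether the 3-nitrophenyl change gives a similar step on the core of compound 2.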